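This account rests on a few compounds, and the source may have more. Where it says the series, first, only, none or still open, it means among the compounds named here.

Measured in a functional assay on the whole organism for antagonist activity, with Mus musculus as the target; a lower number here means that less compound is needed, a higher number that more compound is needed for the effect:
- compound 1 `CCC(=O)NCC(=O)N(C)c1ccc(Cl)cc1C(=O)c1ccccc1Cl`: 1.4 mg/kg
- compound 2 `CCCCCCC(=O)NCC(=O)N(C)c1ccc(Cl)cc1C(=O)c1ccccc1Cl`: 1.9 mg/kg
- compound 3 `CCCC(=O)NCC(=O)N(C)c1ccc(Cl)cc1C(=O)c1ccccc1Cl`: 0.98 mg/kg

Compound 3, at 0.98 mg/kg, lies within the scatter of both other compounds. Compound 4 `CN(C(=O)CNC(=O)CN1CCN(c2ccccc2)CC1)c1ccc(Cl)cc1C(=O)c1ccccc1Cl` carries 4-phenylpiperazin-1-yl in place of ethyl on a saturated chain carbon bound to a carbonyl carbon. The closest evidence is the set of chain changes: a 1.4-fold lower number from compound 1 to compound 3 (0.15 log units; within the scatter), a 1.4-fold higher number from compound 1 to compound 2 (0.13 log units; within the scatter) and a 1.9-fold lower number from compound 2 to compound 3 (0.29 log units; within the scatter). Going by the values given here, all three stay within the scatter, but they involve only plain chains, and no measured compound carries a ring at this place. A small rise in this assay is therefore expected, with wide uncertainty, and the estimated change is a 1.8-fold higher number from compound 3 to compound 4 (0.26 log units; within the scatter). The estimate for compound 4 is 1.8 mg/kg, with an expected range from 0.5 mg/kg to 7 mg/kg.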

Compound 4, dose for half-maximal effect: 75 mg/kg
The estimate for compound 4 lay 42-fold (1.62 log units) below the measured number, outside the stated range (above it).
By their numbers in this assay, from the lowest: compounds 3, 1 and 2 (each within the scatter of the next); then compound 4.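

In this assay the plain chains on this saturated chain carbon bound to a carbonyl carbon all stay within the scatter of one another, yet 4-phenylpiperazin-1-yl gives a 77-fold higher number from compound 3 to compound 4 (1.88 log units; beyond the scatter) and a 39-fold higher number from compound 2 to compound 4 (1.60 log units; beyond the scatter) and also a 54-fold higher number from compound 1 to compound 4 (1.73 log units; beyond the scatter) in the same series. This position therefore does not accept every group equally: chain length barely registers here, while this ring-bearing group demands far more compound. Nothing measured here explains the rise. Still open, on these data alone, is whether a small amine such as dimethylamino, or piperazin-1-yl without its phenyl ring, would bring a similar rise. As far as these compounds go, a plain phenyl group or a carboxylic acid at this place remains equally open.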